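Aryl sulfonate variation on the shared stilbene core

The source may report more compounds than this note shows. Statements on the series, on what has been measured and on what is new or still open speak of the compounds shown alone.

Going by the values given here, compound 1 `Cc1ccccc1OS(=O)(=O)C1CC2OC1C(c1ccc(/C=C/c3cc(O)cc(O)c3)cc1)=C2c1ccc(O)cc1` is the weaker of the two measured members: in a functional assay on MCF7 cells (Homo sapiens) for antiproliferative activity, read by MTT assay, with a stated time of 72 h (on this read-out lower numbers stand for stronger inhibition and higher numbers for weaker inhibition), compound 1 gives 55800 nM, while compound 2 `O=S(=O)(Oc1cccc(C(F)(F)F)c1)C1CC2OC1C(c1ccc(/C=C/c3cc(O)cc(O)c3)cc1)=C2c1ccc(O)cc1` gives 11500 nM. Among the compounds with values here, the single measured step, a 4.9-fold lower number from compound 1 to compound 2 (0.69 log units; beyond the scatter), exchanges the aryl group on the same oxygen. Compound 3 `O=S(=O)(Oc1cccc2ccccc12)C1CC2OC1C(c1ccc(/C=C/c3cc(O)cc(O)c3)cc1)=C2c1ccc(O)cc1` differs from compound 1 by naphthalen-1-yl in place of 2-methylphenyl on an oxygen. Within the data shown here, no measured step matches this change; the step to compound 2 only shows that swapping this aryl group can move the number beyond the scatter. A lower number, expected to be about a 2.5-fold lower number from compound 1 to compound 3 (0.40 log units; beyond the scatter), follows. Compound 3 is estimated at 22000 nM, range 7000 nM to 65000 nM.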

Compound 3, half-maximal inhibitory concentration: 11000 nM
Compound 3: the middle estimate sits 2.0-fold (0.30 log units) above what was measured; low and high end bracket the measured number.
By their numbers in this assay, from the lowest: compounds 3 and 2 (each within the scatter of the next); then compound 1.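

On the oxygen bound to the sulfonyl sulfur, naphthalen-1-yl in place of 2-methylphenyl gives a 5.1-fold lower number from compound 1 to compound 3 (0.71 log units; beyond the scatter) in this assay and so provides a second aryl group that separates from compound 1. Naphthalen-1-yl in place of 3-(trifluoromethyl)phenyl gives a 1.0-fold lower number from compound 2 to compound 3 (0.02 log units; within the scatter) and so leaves these two aryl groups unresolved on this read-out. No available evidence bears on the origin of these differences.

As far as these compounds go, whether an aryl group is needed on this oxygen remains open. A plain methyl group, a butyl chain, or a phenyl ring carrying an amine or a carboxylic acid lies outside the compounds shown.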